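This account rests on a few compounds, and the source may have more. Where it says the series, first, only, none or still open, it means among the compounds named here.

Measured compounds:
compound 1 `Cc1ccc(-c2cs/c(=N/NC(=O)CSc3nnnn3-c3ccccc3)n2-c2ccccc2)cc1` — 14.7 ug/mL
compound 2 `Cn1cnnc1SCC(=O)N/N=c1/scc(-c2ccc(Br)cc2)n1-c1ccccc1` — "not determined" (no result reported)
compound 3 `COc1ccc(-c2cs/c(=N/NC(=O)CSc3nnc(C)s3)n2-c2ccccc2)cc1` — 18.7 ug/mL

The series was examined in a functional assay on C6 cells (Rattus norvegicus) for cytotoxicity, read by MTT assay, with a stated time of 24 h; a higher number here means a weaker inhibitor, a lower number a stronger inhibitor. In this assay compound 1 gives 14.7 ug/mL, and compound 3 gives 18.7 ug/mL; the two numbers lie within the usual scatter of each other, so neither compound can be set apart from the other. For compound 2 no result was reported in this assay. Going by the values given here, with only two numbers in hand, compound 1 stands at the lower of the two, yet without a gap that means anything.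

The account follows the step from compound 1 to compound 4 `O=C(CSc1nnnn1-c1ccccc1)N/N=c1/scc(-c2ccc(F)cc2)n1-c1ccccc1`. The change is fluoro in place of methyl on an aromatic carbon, a swap of one heavy atom for one heavy atom on the six-membered aromatic ring of carbon only. Nothing measured in this series shows how this swap behaves, so the expectation for compound 4 rests on compound 1 alone: the step from compound 1 to compound 4 is expected to stay within the scatter, with no direction claimed, as a 1.0-fold higher number from compound 1 to compound 4 (0.01 log units; within the scatter). Compound 4 is therefore estimated at 15 ug/mL, between 7 ug/mL and 32 ug/mL.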

Compound 4, half-maximal inhibitory concentration: 24.3 ug/mL
The estimate for compound 4 lay 1.6-fold (0.21 log units) below the measured number; low and high end bracket the measured number.
By their numbers in this assay, from the lowest: compounds 1, 3 and 4 (each within the scatter of the next).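

In this assay, fluoro in place of methyl on an aromatic carbon, para to a large group, gives a 1.7-fold higher number from compound 1 to compound 4 (0.22 log units; within the scatter). Going by these compounds alone, this is the first comparison of compounds that differ in one place, and it shows that this change at this position does not move the number beyond the scatter, so 4-methylphenyl and 4-fluorophenyl cannot be told apart here. Nothing measured on these compounds speaks to a cause for this result.

The compounds shown leave open whether an amine or a carboxylic acid on this same aromatic carbon would give a step beyond the scatter. They also leave open whether fluoro in place of methyl reads the same way on a core other than that of compound 1, for this single step is the only one available.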